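Cyclobutylmethoxy in Place of Butoxy on the Pyridine Side

The source may hold more compounds than are shown below. What is called first, only, known or untested is meant among the compounds shown, and "the series" means these compounds.

Measured compounds:
- compound 1 `CC1CCN(c2nc(C(F)(F)F)ccc2CNC(=O)Nc2cccc3c(=O)[nH]ccc23)CC1`: 9.59 nM
- compound 2 `O=C(NCc1ccc(C(F)(F)F)nc1N1CCCCC1)Nc1cccc2c(=O)[nH]ccc12`: 13.2 nM
- compound 3 `CCCCOc1nc(C(F)(F)F)ccc1CNC(=O)Nc1cccc2c(=O)[nH]ccc12`: 160 nM

All three share one core and differ only in the group on the aromatic carbon bearing the trifluoromethyl ring. In an assay on CHO cells for agonist activity at transient receptor potential cation channel subfamily V member 1 (Homo sapiens) (a higher number here means that more compound is needed for the effect, a lower number that less compound is needed), compound 1 gives 9.59 nM and compound 2 gives 13.2 nM; the step of a 1.4-fold higher number from compound 1 to compound 2 (0.14 log units; within the scatter) is small. Compound 3, carrying a butoxy group, gives 160 nM, the highest number among the three: a 17-fold higher number from compound 1 to compound 3 (1.22 log units; beyond the scatter) and a 12-fold higher number from compound 2 to compound 3 (1.08 log units; beyond the scatter).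

Compound 4 `O=C(NCc1ccc(C(F)(F)F)nc1OCC1CCC1)Nc1cccc2c(=O)[nH]ccc12` has not yet been measured. It differs from compound 3 by cyclobutyl in place of propyl on a saturated chain carbon bound to an oxygen on an aromatic ring. Among the measured compounds shown here, no measured step here changes the alkoxy chain itself; the two large steps both swap a nitrogen ring for butoxy, so they say nothing about reshaping that chain. With no guidance either way, the step of a 1.2-fold lower number from compound 3 to compound 4 (0.09 log units; within the scatter) is expected to stay within the scatter. Compound 4 is therefore expected to give about 130 nM, with a plausible range from 40 nM to 500 nM.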

Compound 4, half-maximal effective concentration: 63.2 nM
Compound 4: middle estimate off by 2.1-fold (0.31 log units), on the high side; low and high end bracket the measured number.
By their numbers in this assay, from the lowest: compounds 1 and 2 (each within the scatter of the next); then compound 4; then compound 3.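

In this assay, among the compounds shown here, replacing propyl with cyclobutyl gives a 2.5-fold lower number from compound 3 to compound 4 (0.40 log units; beyond the scatter) and is the first sign that this position responds to a change inside the oxygen-linked group, not only to swapping that group for a nitrogen ring. The change recovers only part of the distance to those rings, with a 4.8-fold higher number from compound 2 to compound 4 (0.68 log units; beyond the scatter) and a 6.6-fold higher number from compound 1 to compound 4 (0.82 log units; beyond the scatter) still separating cyclobutylmethoxy from piperidin-1-yl and 4-methylpiperidin-1-yl. Among the groups shown on this aromatic carbon, both oxygen-linked groups therefore give higher numbers than the two nitrogen rings.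

As far as these compounds go, whether the ring or the added carbon matters stays open, and a pentyloxy chain or a cyclopropylmethoxy group would help separate the two. The data shown offer no measurement that explains this step.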